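Pyridone amide series: same aryl change on two cores

A few compounds are considered here, and "the series" means these few. Any claim that something is new, unique, unknown or untested is made for them only; others in the source may bear on it.

Measured so far in a functional assay on MCF7 cells (Homo sapiens) for cytotoxicity, read by MTT assay, with a stated time of 72 h; a higher number here means a weaker inhibitor, a lower number a stronger inhibitor:
compound 1 `O=C(Nc1ccc(Oc2ccnc3[nH]ccc23)c(F)c1)c1nn(-c2ccccc2)ccc1=O`: 34900 nM
compound 2 `O=C(Nc1ccc(Oc2ccnc3[nH]ccc23)c(F)c1)c1nn(-c2ccc(Br)cc2F)ccc1=O`: 23500 nM
compound 3 `Cn1ccc2c(Oc3ccc(NC(=O)c4nn(-c5ccccc5)ccc4=O)cc3)ccnc21`: 45200 nM

In this assay the step of a 1.5-fold lower number from compound 1 to compound 2 (0.17 log units; within the scatter) is the change (4-bromo-2-fluorophenyl in place of phenyl on an aromatic nitrogen). The three values lie within the scatter of one another, so no order among compound 1, compound 2 and compound 3 is read from them. The difference between the core of compound 1 and the core of compound 3 is not broken down here.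

Compound 4 `Cn1ccc2c(Oc3ccc(NC(=O)c4nn(-c5ccc(Br)cc5F)ccc4=O)cc3)ccnc21` is not yet measured. It carries the same change as compound 2, (4-bromo-2-fluorophenyl in place of phenyl on an aromatic nitrogen), on the core of compound 3. Because the step of a 1.5-fold lower number from compound 1 to compound 2 (0.17 log units; within the scatter) was within the scatter, compound 4 is expected to give a number close to that of compound 3, the estimated step being a 1.5-fold lower number from compound 3 to compound 4 (0.18 log units; within the scatter). For compound 4 the estimate in this assay is 30000 nM, with a range of 15000 nM to 60000 nM.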

Compound 4, half-maximal inhibitory concentration: 19800 nM
Beside the measured number, compound 4's estimate is 1.5-fold (0.18 log units) above it, within the range that was stated.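

In this assay the change to 4-bromo-2-fluorophenyl gives a 2.3-fold lower number from compound 3 to compound 4 (0.36 log units; beyond the scatter), a modest step. The step on the core of compound 3 and the step on the core of compound 1 do not differ beyond the scatter: the same change on two cores in this assay, a 1.5-fold lower number (0.17 log units; within the scatter) from compound 1 to compound 2 and a 2.3-fold lower number (0.36 log units; beyond the scatter) from compound 3 to compound 4, 1.5-fold (0.19 log units) apart, within the scatter of two such steps. For the compounds shown here, the change therefore carries across these two cores with no detectable difference in size, but the step lies beyond the scatter on only one core, and two cores do not establish a rule for the series.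

The compounds shown leave open what bromine and fluorine each contribute, since they enter only together. Also open, going by these compounds, is how an amine or a carboxylic acid on the phenyl would read in this assay.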